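From an aromatic ring to a saturated one on the chain

The source may report more compounds than this note shows. Statements on the series, on what has been measured and on what is new or still open speak of the compounds shown alone.

Compound 1 `Cc1cc(OCCCCCCC[N+]2(C)CCCC2)cc(-n2cc(C(=O)Nc3cc(F)cc(F)c3)c(=O)c3ccc(N(C)C)nc32)c1`: 35.4%
Compound 2 `Cc1cc(OCCCCCCC[n+]2ccccc2)cc(-n2cc(C(=O)Nc3cc(F)cc(F)c3)c(=O)c3ccc(N(C)C)nc32)c1`: 61%
Compound 3 `CC[N+]1(CCCCCCCOc2cc(-n3cc(C(=O)Nc4cc(F)cc(F)c4)c(=O)c4ccc(N(C)C)nc43)ccc2Cl)CCCCC1`: "not active" (no number reported)

All three were tested in an assay on LX2 cells for inhibition of COL1A1 promoter (Homo sapiens), read by a luciferase reporter, with a stated time of 24 h, tested at 50 uM; a lower number here means a weaker effect, a higher number a stronger effect of the compound at the concentration tested. Compound 2 has the highest of the two numbers; its nearest neighbour is compound 1, and a number 25.6 percentage points higher from compound 1 to compound 2 (beyond the scatter). Compound 4 `Cc1cc(OCCCCCCC[N+](C)(C)C2CCCCC2)cc(-n2cc(C(=O)Nc3cc(F)cc(F)c3)c(=O)c3ccc(N(C)C)nc32)c1` differs from compound 2 in one place: a group of 9 heavy atoms (8 carbon, 1 nitrogen; one six-membered non-aromatic ring of carbon only) in place of a group of 6 heavy atoms (5 carbon, 1 nitrogen; one six-membered aromatic ring with 1 hetero atom), on a saturated chain carbon, seven bonds along the chain from an oxygen on an aromatic ring. Among the measured compounds shown here, the single step that bears on this change is the one from compound 1 to compound 2, where a six-membered aromatic ring with one hetero atom took the place of a five-membered non-aromatic ring and the read-out rose by a modest amount. Compound 4 goes back to a non-aromatic ring, and compound 3, which also carries a non-aromatic ring but on a different core, was not active. A drop beyond the scatter is therefore expected, a number 21 percentage points lower from compound 2 to compound 4 (beyond the scatter). Compound 4 is estimated at 40%, with a range from 20% to 60%.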

Compound 4, a percentage reported as inhibition, at one concentration (the size of the read-out at that concentration, not a potency): 89.1%
Beside the measured number, compound 4's estimate is 49.1 percentage points below it; the measured number lies above the stated range.
By their numbers in this assay, from the lowest: compound 1; then compound 2; then compound 4.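

At this place on the chain, an aromatic ring is not needed for a high read-out in this assay: the six-membered non-aromatic ring of carbon only gives a number 28.1 percentage points higher from compound 2 to compound 4 (beyond the scatter). The two non-aromatic groups also stand far apart, with a number 53.7 percentage points higher from compound 1 to compound 4 (beyond the scatter), so the aromatic or non-aromatic nature of the ring alone does not order these compounds. No measurement here explains these differences. Still open, from the compounds shown here alone, is whether a trimethylammonium group, with no ring at all, would hold this read-out, and what a longer chain would do.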